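The source may report more compounds than this note shows. Statements on the series, on what has been measured and on what is new or still open speak of the compounds shown alone.

In an assay on HEK293 cells for displacement of a labelled ligand from Translocator protein (Homo sapiens), read by scintillation counting, with a stated time of 90 min (on this read-out lower numbers stand for stronger inhibition and higher numbers for weaker inhibition), compound 2 `CCN(CC)C(=O)CN(Cc1ccc(OC)cc1)c1cc(C)cc(C)c1` gives 4210 nM, the higher of the two numbers recorded so far; the nearest is compound 1 `CC(=O)N(Cc1ccc(OC(C)C)cc1)c1cc(C)cc(C)c1`, which gives 3150 nM, a gap that lies within the scatter. Compound 3 `CCN(CC)C(=O)CN(Cc1ccc(OC(C)C)cc1)c1cc(C)cc(C)c1` differs from compound 2 by isopropyl in place of methyl on an oxygen on an aromatic ring. Going by the values given here, no pair of measured compounds isolates this change, and compound 1 differs from compound 2 in two places, so its value says nothing about this exchange alone. The step of a 1.3-fold lower number from compound 2 to compound 3 (0.12 log units; within the scatter) is therefore expected to stay within the scatter. Compound 3 is estimated at 3200 nM, with a range from 1000 nM to 10000 nM.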

Compound 3, inhibition constant: > 10000 nM
Compound 3: only a limit was reported; the forecaster's own chance of this, stated with the estimate: 5%; at least 3.1-fold (0.49 log units) between middle value and limit.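

In this assay, going by these compounds alone, the reading for compound 3 is a limit and not a number: the limit of > 10000 nM in this assay, at which 1 of the 3 values shown sits. Methoxy to isopropoxy on the oxygen, a change the earlier compounds did not isolate, matters when (diethylcarbamoyl)methyl sits on the nitrogen, giving an at least 2.3-fold higher number from compound 2 to compound 3 (0.37 log units; beyond the scatter). With isopropoxy held fixed, (diethylcarbamoyl)methyl in place of acetyl gives an at least 3.1-fold higher number from compound 1 to compound 3 (0.50 log units; beyond the scatter), so the two groups together read weaker than either does without the other.

From the compounds shown here alone, how far the true number of compound 3 lies past the limit stays open. So does the outcome with ethyl or cyclopropyl on that oxygen, or with acetyl on the nitrogen alongside methoxy.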